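The compounds below may be only part of what the source reports. "The series", "measured", "known", "first", "only" and "open" are said of these compounds alone.

The study turns on two measured compounds and one awaiting a number. Compound 2 `CCOC(=O)c1cccc(-c2ccc(N(C)C)cc2)c1` stands at the top of the two values in an assay on COS-7 cells for inhibition of patatin-like phospholipase domain-containing protein 2 (Mus musculus), tested at 200 uM (on this read-out lower numbers stand for less inhibition and higher numbers for more inhibition at the one concentration tested (going by the name of the read-out)), where compound 2 gives 87%. Its nearest neighbour is compound 1 `CCOC(=O)c1cncc(-c2ccc(OCC)cc2)c1`, which in this assay gives 70%, a value lower by a gap that lies beyond the usual scatter. For the measured compounds named here, no step between these two has been worked out, so their two values simply show that compound 2 reaches the higher inhibition.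

The piece now follows the move to compound 3 `CCOC(=O)c1cccc(-c2ccc(CN3CCCC3)cc2)c1`, which differs from compound 2 in one place: (pyrrolidin-1-yl)methyl in place of dimethylamino on an aromatic carbon. Going by the values given here, no measured pair tells how such a change plays out here, so the expectation rests on the value of compound 2 alone. Compound 3 is expected to stay in the same region in this assay, with a step of a number 9 percentage points lower from compound 2 to compound 3 (within the scatter) that is not expected to exceed the scatter. The estimate for compound 3 in this assay is 78%, within a range from 55% to 95%.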

Compound 3, a percentage reported as inhibition, at one concentration (the size of the read-out at that concentration, not a potency): 33%
Compound 3: middle estimate off by 45 percentage points, on the high side, and the stated range ends above it.
By their numbers in this assay, from the lowest: compound 3; then compound 1; then compound 2.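

In this assay, putting (pyrrolidin-1-yl)methyl in place of dimethylamino on this aromatic carbon, para to a large group, comes with a number 54 percentage points lower from compound 2 to compound 3 (beyond the scatter) and so shows that the inhibition depends strongly on what this position carries, which the earlier pair, differing in more than one place, could not show. The two groups match in their count of one nitrogen, one hydrogen-bond acceptor and no net charge, so that match alone does not preserve the inhibition. The data offer no measurement that accounts for the drop.

The compounds shown leave open which part of the change matters, since dimethylaminomethyl would keep the open-chain amine with a carbon link, while pyrrolidin-1-yl on the aromatic carbon would keep the ring without that link. On these data alone, how a morpholine ring or a carboxylic acid would read out at this position also remains open.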